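This account rests on a few compounds, and the source may have more. Where it says the series, first, only, none or still open, it means among the compounds named here.

Among the compounds with values here, in an assay on isolated protein for binding affinity to Adrenergic receptor alpha-1 (Homo sapiens), read by radioligand binding (a lower number here means a stronger inhibitor, a higher number a weaker inhibitor), compound 1 `Oc1ccc(CC(O)CN2CCC(Cc3ccccc3)CC2)cc1` gives 305 nM, the second highest of the three numbers known so far. Compound 2 `Oc1ccc(C(O)CCN2CCC(Cc3ccccc3)CC2)cc1` gives 24.4 nM, and compound 3 `Oc1ccc(CC(O)CN2CCC(O)(Cc3ccccc3)CC2)cc1` gives 4510 nM. Within the data shown here, the one step measured between neighbours, a 15-fold higher number from compound 1 to compound 3 (1.17 log units; beyond the scatter), placed hydroxy on a saturated ring carbon and made the number much higher.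

Compound 4 `COC(Cc1ccc(O)cc1)CN1CCC(Cc2ccccc2)CC1` differs from compound 1 by methyl in place of hydrogen on an oxygen on a saturated carbon, that is, hydroxy becomes methoxy. Among the measured compounds shown here, no measured step changes this oxygen, so the bearing of the known data is indirect; the only measured step, a 15-fold higher number from compound 1 to compound 3 (1.17 log units; beyond the scatter), shows that this core reacts strongly to a small change near the alcohol.

A moderately higher number is therefore expected, a 2.6-fold higher number from compound 1 to compound 4 (0.42 log units; beyond the scatter), and compound 4 is estimated at 800 nM, within 200 nM to 3200 nM.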

Compound 4, inhibition constant: 305 nM
Compound 4: middle estimate off by 2.6-fold (0.42 log units), on the high side; the measured number falls inside the stated range.
By their numbers in this assay, from the lowest: compound 2; then compounds 1 and 4 (each within the scatter of the next); then compound 3.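

In this assay, capping the oxygen on a saturated carbon with methyl gives no change at the digits printed from compound 1 to compound 4 (within the scatter), so hydroxy and methoxy cannot be told apart here. The core is therefore not sensitive to every small change: adding hydroxy on a saturated ring carbon gave a 15-fold higher number from compound 1 to compound 3 (1.17 log units; beyond the scatter), while this change did not move the number. Nothing measured here explains why the methyl makes no difference. Still open, as far as these compounds go, is whether a longer chain on this oxygen, such as ethyl or benzyl, would also leave the number in place, and whether an amine could replace the oxygen.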